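Amine exchange on the shared core: compound 3 to compound 4

A few compounds are considered here, and "the series" means these few. Any claim that something is new, unique, unknown or untested is made for them only; others in the source may bear on it.

Values in a functional assay on SW-620 cells (Homo sapiens) for inhibition, read by MTT assay, with a stated time of 72 h; on this read-out lower numbers stand for stronger inhibition and higher numbers for weaker inhibition:
- compound 1 `COc1ccc(CNCc2c(OC)cc(Oc3cccc(Nc4ccccc4)c3)cc2OC)cc1`: 6970 nM
- compound 2 `COc1ccc(CCCNCc2c(OC)cc(Oc3cccc(Nc4ccccc4)c3)cc2OC)cc1`: 6400 nM
- compound 3 `CCN1CCN(Cc2c(OC)cc(Oc3cccc(Nc4ccccc4)c3)cc2OC)CC1`: > 20000 nM (a limit, not a number)

Compound 3 has only a limit in this assay, > 20000 nM, and no measured number.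

Compound 4 `COc1cc(Oc2cccc(Nc3ccccc3)c2)cc(OC)c1CN(C)C` differs from compound 3 by one change on a saturated chain carbon bound to an aromatic carbon, with dimethylamino in place of 4-ethylpiperazin-1-yl on a saturated chain carbon bound to an aromatic carbon.

For the measured compounds named here, no measured step makes this exchange directly. The nearest are an at least 2.8-fold higher number from compound 1 to compound 3 (0.45 log units; beyond the scatter) and an at least 3.1-fold higher number from compound 2 to compound 3 (0.49 log units; beyond the scatter), both beyond the scatter and both ending at a limit, so their true size is open. The remaining step, a 1.1-fold lower number from compound 1 to compound 2 (0.04 log units; within the scatter), lies within the scatter. Compound 4 lacks the 4-methoxyphenyl group, as compound 3 does, so given an at least 3.1-fold higher number from compound 2 to compound 3 (0.49 log units; beyond the scatter) it is expected to read closer to compound 3 than to compound 2. Only a small move towards a lower number is expected, and a second limit would be no surprise. The expected step is an at least 1.2-fold lower number from compound 3 to compound 4 (0.09 log units; that floor lies within the scatter). The estimate for compound 4 is 16000 nM, with an expected range of 7000 nM to 40000 nM.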

Compound 4, half-maximal inhibitory concentration: > 20000 nM
Compound 4: no number, only a limit (the forecaster's own chance of this, stated with the estimate: 45%); middle value at least 1.2-fold (0.09 log units) from the limit.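

In this assay compound 4 gives > 20000 nM, which is a limit and not a number. The two amines lacking the 4-methoxyphenyl group now both sit apart from the measured compounds, with an at least 2.8-fold higher number from compound 1 to compound 4 (0.45 log units; beyond the scatter) and an at least 3.1-fold higher number from compound 2 to compound 4 (0.49 log units; beyond the scatter), so on this saturated chain carbon bound to an aromatic carbon the higher reading does not depend on a ring at the amine: dimethylamino, with 3 heavy atoms and no ring, ends in the same place as the 4-ethylpiperazin-1-yl of compound 3, with 8 heavy atoms and one ring. The step between compound 3 and compound 4 cannot be read, and the series now shows a shared ceiling at this position: the limit of > 20000 nM in this assay, at which 2 of the 4 values shown sit.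

Going by these compounds, whether dimethylamino and 4-ethylpiperazin-1-yl truly differ remains open, with neither compound holding a number in this assay. Also open, on these data alone, is whether the measured values of compound 1 and compound 2 depend on the 4-methoxyphenyl group or on the secondary amine, which a plain benzylamino group or a simple methylamino group on the same carbon would help to separate.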